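Swapping a heptyl chain for 2-methoxyethynyl

A few compounds are considered here, and "the series" means these few. Any claim that something is new, unique, unknown or untested is made for them only; others in the source may bear on it.

Of the compounds shown here, three sharing one core have been tested in a functional assay on A-431 cells (Homo sapiens) for inhibition; a lower number here means a stronger inhibitor, a higher number a weaker inhibitor. Compound 1 (`CCCCCCC[C@H]1O[C@@H]2OC(=O)N(C(=O)CCl)[C@@H]2CC1=O`) gives 79000 nM. Compound 2 (`CCCCCCC[C@@]1(C)O[C@@H]2OC(=O)N(C(=O)CCl)[C@@H]2CC1=O`) gives 78000 nM, which lies within the scatter of the value for compound 1. Compound 3 (`CCCCCC#C[C@]1(C)O[C@@H]2OC(=O)N(C(=O)CCl)[C@@H]2CC1=O`) gives 5000 nM, a clearly lower number and so a stronger inhibitor. Compound 2 therefore stands at the high, weakly inhibiting end of this small set, level with compound 1 and well above compound 3.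

The next compound, compound 4 (`COC#C[C@@]1(C)O[C@@H]2OC(=O)N(C(=O)CCl)[C@@H]2CC1=O`), keeps the core but carries 2-methoxyethynyl in place of heptyl on a saturated ring carbon. For the measured compounds named here, no measured pair shows this change on its own, so any forecast is loose. The side chain of compound 3 also holds a triple bond, and compound 3 reads 5000 nM, which hints that a triple bond here may go with a lower number. The entering group is smaller than heptyl, however, so only part of that gap is expected to carry over. The estimated change in this assay is a 3.9-fold lower number from compound 2 to compound 4 (0.59 log units; beyond the scatter), a moderate fall that would lie beyond the scatter, although no real change cannot be ruled out. Compound 4 is expected at 20000 nM, with an estimated range of 5000 nM to 90000 nM.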

Compound 4, half-maximal inhibitory concentration: 64000 nM
Estimate against measurement, compound 4: 3.2-fold (0.51 log units) below; the range from low to high includes it.
By their numbers in this assay, from the lowest: compound 3; then compounds 4, 2 and 1 (each within the scatter of the next).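

In this assay, putting 2-methoxyethynyl in place of heptyl on this saturated ring carbon gives a 1.2-fold lower number from compound 2 to compound 4 (0.09 log units; within the scatter), so a much smaller group that also brings a triple bond and a hydrogen-bond acceptor leaves the reading unchanged within the scatter. Compound 4 shares a triple bond in its side chain with compound 3, yet compound 3 gives 5000 nM and compound 4 gives 64000 nM, so a triple bond on this carbon does not by itself bring the number down to that of compound 3. Nothing available here explains why compound 2 and compound 4 read alike.

What the compounds shown leave open is whether the lower number of compound 3 depends on the length of its chain, on the absence of the methoxy oxygen, or on both. A butynyl or pentynyl group on the same carbon would help separate these possibilities, while a 2-methoxyethyl group would show how the oxygen-bearing chain reads without its triple bond.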